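Two Linkers, One Benzyl Swap, and an Expected Gain

This account rests on a few compounds, and the source may have more. Where it says the series, first, only, none or still open, it means among the compounds named here.

Four close relatives share a core in which a toluene-like ring bearing a benzimidazole is joined through a two-carbonyl or thiourea-carbonyl linker to a phenyl ether. Compound 1 `Cc1ccc(NC(=S)NC(=O)c2ccc(OCc3cccc(F)c3)cc2)cc1-c1nc2ccccc2[nH]1` and compound 2 `Cc1ccc(NC(=S)NC(=O)c2ccc(OCc3ccccc3Cl)cc2)cc1-c1nc2ccccc2[nH]1` carry the thiourea linker; compound 3 `Cc1ccc(NC(=O)NC(=O)c2ccc(OCc3cccc(F)c3)cc2)cc1-c1nc2ccccc2[nH]1` and the still unmeasured compound 4 `Cc1ccc(NC(=O)NC(=O)c2ccc(OCc3ccccc3Cl)cc2)cc1-c1nc2ccccc2[nH]1` carry the urea linker. The difference between the two cores is not broken down here.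

In a functional assay on MGC-803 cells (Homo sapiens) for inhibition, read by MTT assay, with a stated time of 48 h (on this read-out lower numbers stand for stronger inhibition and higher numbers for weaker inhibition), compound 1 reaches only the limit > 100000 nM, which is a boundary of the measurement rather than a number (the limit of > 100000 nM in this assay, at which 1 of the 3 values shown sits). Compound 2 gives 45000 nM in this assay, and compound 3 gives 44800 nM.

The change from compound 1 to compound 2 is 2-chlorophenyl in place of 3-fluorophenyl on a saturated chain carbon bound to an oxygen on an aromatic ring, and it brought an at least 2.2-fold lower number from compound 1 to compound 2 (0.34 log units; beyond the scatter). Compound 4 carries the same change relative to compound 3, namely (2-chlorophenyl in place of 3-fluorophenyl on a saturated chain carbon bound to an oxygen on an aromatic ring).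

Because that earlier step gave an at least 2.2-fold lower number from compound 1 to compound 2 (0.34 log units; beyond the scatter), compound 4 is expected to show a comparable step of a 2.0-fold lower number from compound 3 to compound 4 (0.31 log units; beyond the scatter) in this assay. Compound 4 is therefore estimated at 22000 nM, with a plausible span from 8000 nM to 60000 nM.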

Compound 4, half-maximal inhibitory concentration: 19500 nM
Estimate against measurement, compound 4: 1.1-fold (0.05 log units) above; the range from low to high includes it.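

In this assay, the swap from 3-fluorobenzyl to 2-chlorobenzyl on the urea core gave a 2.3-fold lower number from compound 3 to compound 4 (0.36 log units; beyond the scatter), so the number falls on this core as it did on the thiourea core. Set side by side, the two steps compare as follows: the same change on two cores in this assay, an at least 2.2-fold lower number (0.34 log units; beyond the scatter) from compound 1 to compound 2 and a 2.3-fold lower number (0.36 log units; beyond the scatter) from compound 3 to compound 4; the limit leaves it open whether they differ. From the compounds shown here alone, compound 1 gives > 100000 nM, which is a limit and not a number, so the full size of the step on the thiourea core stays unknown, and two cores cannot show that the change would carry over to every other core.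

The swap replaces fluorine with chlorine and moves the halogen in a single step, so the compounds shown leave open which of these two differences drives the lower number. They also leave open how the same cores would respond to a plain benzyl group with no halogen, or to a benzyl ring bearing a methoxy group or a carboxylic acid.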